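The source may report more compounds than this note shows. Statements on the series, on what has been measured and on what is new or still open speak of the compounds shown alone.

The three measured compounds share one core and differ only in the ring attached to the amide nitrogen. Compound 1 `CCOc1ccc(NC(=O)c2cccc(/C=C3\CC(=O)N(c4ccccc4)C3=O)c2)cc1` carries a 4-ethoxyphenyl group there, and in an ADME assay on HCT-116 cells (Homo sapiens) for cytotoxicity, read by MTT assay, with a stated time of 72 h (a lower number here means a stronger inhibitor, a higher number a weaker inhibitor), compound 1 gives 84800 nM. Compound 2 `CCc1cccc(NC(=O)c2cccc(/C=C3\CC(=O)N(c4ccccc4)C3=O)c2)c1` carries a 3-ethylphenyl group, and in this assay compound 2 gives 81200 nM. Compound 3 `Cc1cccc(NC(=O)c2cccc(/C=C3\CC(=O)N(c4ccccc4)C3=O)c2)c1` carries a 3-methylphenyl group. For compound 3 the result in this assay is a limit of the assay rather than a number, reported as > 100000 nM. Compound 3 thus sits at the limit of > 100000 nM in this assay, at which 1 of the 3 values shown sits. Its two measured steps, an at least 1.1-fold higher number from compound 1 to compound 3 (0.07 log units; that floor lies within the scatter) and an at least 1.2-fold higher number from compound 2 to compound 3 (0.09 log units; that floor lies within the scatter), both lie within the scatter, as does a 1.0-fold lower number from compound 1 to compound 2 (0.02 log units; within the scatter).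

Compound 4 `O=C(Nc1cccc(F)c1)c1cccc(/C=C2\CC(=O)N(c3ccccc3)C2=O)c1` has not been measured. It differs from compound 3 by fluoro in place of methyl on an aromatic carbon. The measured steps show that exchanging 4-ethoxyphenyl, 3-ethylphenyl and 3-methylphenyl on the amide nitrogen moved this assay by no more than the scatter, so no step beyond the scatter is expected for fluoro in place of methyl either. Compound 4 is therefore expected to give about 95000 nM in this assay, with a range from 45000 nM to 200000 nM, and may well come back only as a limit again. That expectation amounts to an at least 1.0-fold lower number from compound 3 to compound 4 (0.02 log units; that floor lies within the scatter).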

Compound 4, half-maximal inhibitory concentration: > 100000 nM
Compound 4: only a limit was reported; the forecaster's own chance of this, stated with the estimate: 55%; middle value at least 1.0-fold (0.02 log units) away from the limit.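

Fluoro in place of methyl on an aromatic carbon of the amide-side ring gives no measurable number either, and in this assay compound 4 is reported only as a limit of the assay: the limit of > 100000 nM in this assay, at which 2 of the 4 values shown sit. Compound 3 and compound 4 are both limits, so the step between them cannot be read, and whether fluoro and methyl differ at this position remains unknown. The two steps that can be read, an at least 1.2-fold higher number from compound 2 to compound 4 (0.09 log units; that floor lies within the scatter) and an at least 1.1-fold higher number from compound 1 to compound 4 (0.07 log units; that floor lies within the scatter), give only floors within the scatter, so the first halogen in this set shows no separation from the 3-ethylphenyl and 4-ethoxyphenyl groups.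

The compounds shown leave open how far beyond the limit compound 3 and compound 4 actually lie, and whether any group on this ring can bring the number clearly down. An amine or a carboxylic acid on this ring, or a change to the unsubstituted phenyl on the other nitrogen of the shared core, would test whether this assay responds to anything beyond the small carbon, ether and fluoro groups seen so far.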